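Benzyl ether variation at the aryloxy position of the series

The source may report more compounds than this note shows. Statements on the series, on what has been measured and on what is new or still open speak of the compounds shown alone.

Compound 2 `CCN(CC)C(=O)Cc1c(-c2ccc(OCc3ccccc3F)cc2)nn2c(C)cc(C)nc12` gives 0.31 nM in an assay on isolated protein (kidney, strain Wistar) for displacement of a labelled ligand from Translocator protein (Rattus norvegicus), read by scintillation counting, with a stated time of 90 min (a lower number here means a stronger inhibitor, a higher number a weaker inhibitor), and stands lowest of the two numbers measured; compound 1 `CCN(CC)C(=O)Cc1c(-c2ccc(OCC3CCCC3)cc2)nn2c(C)cc(C)nc12` gives 2.1 nM in this assay. For the measured compounds named here, the one measured step, a 6.8-fold lower number from compound 1 to compound 2 (0.83 log units; beyond the scatter), swaps a saturated ring for an aromatic one and does not test the change now at hand. Compound 3 `CCN(CC)C(=O)Cc1c(-c2ccc(OCc3cccc(C(F)(F)F)c3)cc2)nn2c(C)cc(C)nc12` differs from compound 2 by 3-(trifluoromethyl)phenyl in place of 2-fluorophenyl on a saturated chain carbon bound to an oxygen on an aromatic ring. Going by the values given here, no measured step bears directly on this exchange, so a step in this assay of a 1.9-fold higher number from compound 2 to compound 3 (0.29 log units; within the scatter) is expected, likely within the scatter. Compound 3 is estimated at 0.6 nM, in the range 0.2 nM to 2 nM.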

Compound 3, inhibition constant: 0.67 nM
Estimate against measurement, compound 3: 1.1-fold (0.05 log units) below, within the range that was stated.
By their numbers in this assay, from the lowest: compound 2; then compound 3; then compound 1.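

In this assay the exchange of 2-fluorophenyl for 3-(trifluoromethyl)phenyl gives a 2.2-fold higher number from compound 2 to compound 3 (0.33 log units; beyond the scatter) and so registers at this position, though modestly. Against cyclopentyl the new group gives a 3.1-fold lower number from compound 1 to compound 3 (0.50 log units; beyond the scatter) and thus both aromatic groups shown sit lower than the saturated ring. Nothing at hand explains either step.

The exchange alters both the substituent and its place on the ring, so the two contributions cannot be separated. On these data alone, an amine or a carboxylic acid on this ring, or a longer chain on the oxygen, remains open.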